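Working notes: acyclic diamine against piperazine on the benzamide

The source may hold more compounds than are shown below. What is called first, only, known or untested is meant among the compounds shown, and "the series" means these compounds.

Measured so far in a functional assay on KG-1 cells (Homo sapiens) for antiproliferative activity, read by CCK-8 assay, with a stated time of 72 h; on this read-out higher numbers stand for weaker inhibition and lower numbers for stronger inhibition:
- compound 1 `COc1cccc(-c2ccc3c(NC(=O)c4ccc(N5CCN(C)CC5)c(F)c4)n[nH]c3c2)c1F`: > 1000 nM
- compound 2 `COc1ccc(F)c(-c2ccc3c(NC(=O)c4ccc(N(C)CCN(C)C)cc4)n[nH]c3c2)c1F`: 333 nM
- compound 3 `CCN1CCN(c2ccc(C(=O)Nc3n[nH]c4cc(-c5cccc(OC)c5F)ccc34)cc2C(F)(F)F)CC1`: > 1000 nM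

Within the data shown here, compound 2 holds the only numerical value of the three. Compound 1 sits at a limit of this assay, > 1000 nM. Compound 3 likewise sits at a limit, > 1000 nM; this is the limit of > 1000 nM in this assay, at which 2 of the 3 values shown sit.

Compound 4 `COc1ccc(F)c(-c2ccc3c(NC(=O)c4ccc(N5CCN(C)CC5)cc4)n[nH]c3c2)c1F` keeps the core of compound 2 and differs only by 4-methylpiperazin-1-yl in place of (2-(dimethylamino)ethyl)(methyl)amino on an aromatic carbon. Among the measured compounds shown here, no measured pair isolates this change, so the size of the step is open. The two limit values give no direction. A modest loss or no change beyond the scatter in this assay is expected, with the step of a 1.7-fold higher number from compound 2 to compound 4 (0.22 log units; within the scatter). Compound 4 is therefore estimated at 550 nM, within 150 nM to 2000 nM.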

Compound 4, half-maximal inhibitory concentration: 41.5 nM
For compound 4 the middle estimate is 13-fold (1.12 log units) above the measured one; measured number outside the range, below it.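

In this assay, 4-methylpiperazin-1-yl in place of (2-(dimethylamino)ethyl)(methyl)amino gives an 8.0-fold lower number from compound 2 to compound 4 (0.90 log units; beyond the scatter), so the group on this aromatic carbon, para to a large group, clearly affects the read-out with the rest of the molecule held fixed. Both groups have the same heavy-atom and hydrogen-bond acceptor counts, so the step accompanies the ring and not a change in those counts.

Among these compounds, no other step at this position can be read: the limit of > 1000 nM in this assay, at which 2 of the 4 values shown sit. Whether a morpholine or a piperidine bearing a dimethylamino group would match the 4-methylpiperazin-1-yl group remains open.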